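The compounds below may be only part of what the source reports. "The series", "measured", "known", "first", "only" and "open" are said of these compounds alone.

The measured compounds and their values in an ADME assay on L929 cells (Mus musculus) for cytotoxicity, read by resazurin assay, with a stated time of 72 h; on this read-out higher numbers stand for weaker inhibition and lower numbers for stronger inhibition:

Compound 1, `O=C(O)c1ccc(C(=O)/C=C/c2ccc3c(c2)B(O)OC3)cc1`, gives only a limit, > 10 ug/mL.
Compound 2, `Nc1cccc(C(=O)/C=C/c2ccc3c(c2)B(O)OC3)c1`, gives 10 ug/mL.
Compound 3, `CSc1ccc(C(=O)/C=C/c2ccc3c(c2)B(O)OC3)cc1`, gives only a limit, > 10 ug/mL.

Compound 3 therefore stands at the limit of > 10 ug/mL in this assay, at which 2 of the 3 values shown sit; its value is a limit and not a number. Among the measured compounds shown here, the one measured step that touches the same place on the shared core, a step that the two limits leave unreadable from compound 1 to compound 3, runs between two limits, so its size cannot be read. For the measured compounds named here, compound 2 is the only compound that gives a number in this assay, and that number lies at the same concentration as the limit, so the three values give no readable ordering.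

Compound 4 is `O=C(/C=C/c1ccc2c(c1)B(O)OC2)c1ccc(Cl)cc1`. It differs from compound 3 as follows: chloro in place of methylsulfanyl on an aromatic carbon. Going by the values given here, no measured step concerns a chloro group, and the only step at this position is unreadable, so the data give no direction to expect. The step from compound 3 to compound 4 is therefore expected to be a number no higher from compound 3 to compound 4 (the limit leaves the size open), within the usual scatter. For compound 4 in this assay the estimate is 10 ug/mL, with a range from 5 ug/mL to 20 ug/mL, and it is quite likely that only a limit will again be reported.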

Compound 4, half-maximal inhibitory concentration: > 10 ug/mL
Compound 4: a limit, no number; the forecaster's own chance of this, stated with the estimate: 60%; the middle value lies on the limit itself.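

In this assay compound 4 gives > 10 ug/mL, which is a limit and not a number. On this aromatic carbon, para to a large group, chloro now joins carboxy and methylsulfanyl in giving a limit, so three different groups at this place end the same way: the limit of > 10 ug/mL in this assay, at which 3 of the 4 values shown sit. Putting 4-chlorophenyl in place of 3-aminophenyl on the carbonyl carbon gives a number no lower from compound 2 to compound 4 (the limit leaves the size open), while the steps among compound 1, compound 3 and compound 4 run between two limits and cannot be read.

As far as these compounds go, how far compound 1, compound 3 and compound 4 lie beyond their shared limit stays open, so these three cannot be ranked against one another. Also open, from the compounds shown here alone, is whether a hydroxy group or a longer chain such as butyl at this same place would give a number rather than another limit.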